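A few compounds are considered here, and "the series" means these few. Any claim that something is new, unique, unknown or untested is made for them only; others in the source may bear on it.

Compound 1 `O=C(N/N=C/c1ccc(Cl)cc1)c1cccnc1Nc1cccc(C(F)(F)F)c1` is the reference point of this account. In a functional assay on the whole organism (strain Wistar) for inhibition, with Rattus norvegicus as the target, read by paw edema, with a stated time of 2 h, at a dose of 10 mg/kg by the intraperitoneal route (on this read-out higher numbers stand for more inhibition at the one dose given (going by the name of the read-out) and lower numbers for less inhibition), compound 1 gives 52.8%, the highest of the three numbers recorded so far, although its lead over compound 3 lies within the scatter of the method. Compound 2 `COc1ccc(/C=N/NC(=O)c2cccnc2Nc2cccc(C(F)(F)F)c2)cc1` gives 42.4% in this assay, and compound 3 `CN(C)c1ccc(/C=N/NC(=O)c2cccnc2Nc2cccc(C(F)(F)F)c2)cc1` gives 51.4%. The steps among these three are a number 10.4 percentage points lower from compound 1 to compound 2 (beyond the scatter), a number 1.4 percentage points lower from compound 1 to compound 3 (within the scatter) and a number 9 percentage points higher from compound 2 to compound 3 (within the scatter).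

Compound 4 `O=C(N/N=C/c1ccncc1)c1cccnc1Nc1cccc(C(F)(F)F)c1` differs from compound 1 by pyridin-4-yl in place of 4-chlorophenyl on a carbon with a double bond to nitrogen. The three measured steps all concern a substituent on that same ring, and they do bear on the new step, but only loosely: none of them replaces the ring itself, and only one of them, the step from compound 1 to compound 2, leaves the scatter. A modest change in either direction is therefore possible, but no step beyond the scatter is expected with confidence in this assay.

For compound 4 the value expected in this assay is 45%, with a range from 30% to 60%. This estimate means an expected step of a number 7.8 percentage points lower from compound 1 to compound 4 (within the scatter).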

Compound 4, a percentage reported as inhibition, in the whole organism at one dose (the size of the read-out at that dose, not a potency): 65.2%
For compound 4 the middle estimate is 20.2 percentage points below the measured one; measured number above the stated range.
By their numbers in this assay, from the lowest: compounds 2, 3 and 1 (each within the scatter of the next, the first and the last beyond it); then compound 4.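

In this assay the aromatic ring on the carbon with a double bond to nitrogen proves to be a more productive point of change than the substituents so far placed on it: pyridin-4-yl in place of 4-chlorophenyl gives a number 12.4 percentage points higher from compound 1 to compound 4 (beyond the scatter), the exchange for 4-(dimethylamino)phenyl gives a number 13.8 percentage points higher from compound 3 to compound 4 (beyond the scatter), and the exchange for 4-methoxyphenyl gives a number 22.8 percentage points higher from compound 2 to compound 4 (beyond the scatter). All three steps lie beyond the scatter, so compound 4 stands clear of every other compound shown, whereas among the substituted phenyl compounds only the step between compound 1 and compound 2 had left the scatter. Nothing available here explains why this ring exchange goes with the higher number.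

The exchange removes the chlorine and brings in a ring nitrogen in one move, so the compounds shown do not separate these two changes, and plain phenyl would be the group needed to begin doing so. They also leave open whether the result belongs to pyridin-4-yl alone or extends to pyridin-3-yl, pyridin-2-yl or a five-membered ring such as furan-2-yl at the same place.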